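From 4-hydroxyphenyl to 4-chlorophenyl in a small series

The source may hold more compounds than are shown below. What is called first, only, known or untested is meant among the compounds shown, and "the series" means these compounds.

Measured so far in a functional assay on MDA-MB-231 cells (Homo sapiens) for antiproliferative activity, read by MTT assay, with a stated time of 24 h; a higher number here means a weaker inhibitor, a lower number a stronger inhibitor:
- compound 1 `COc1ccc(-c2noc(-c3ccncc3)n2)cc1OC1CCCC1` gives 240000 nM
- compound 2 `COc1ccc(-c2noc(-c3cccnc3)n2)cc1OC1CCCC1` gives > 1000000 nM (a limit of the assay, not a number)
- compound 3 `COc1ccc(-c2noc(-c3ccc(O)cc3)n2)cc1OC1CCCC1` gives 310 nM

Compound 3 holds the lower of the two true numbers, and its gap to compound 1, the nearest, is large. The next compound is compound 4 `COc1ccc(-c2noc(-c3ccc(Cl)cc3)n2)cc1OC1CCCC1`, with chloro in place of hydroxy on an aromatic carbon, para to a large group: chloro in place of hydroxy on an aromatic carbon.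

Going by the values given here, no measured step makes this exchange alone. The closest evidence is the replacement of a pyridinyl group by 4-hydroxyphenyl, which gave a 770-fold lower number from compound 1 to compound 3 (2.89 log units; beyond the scatter) and an at least 3200-fold lower number from compound 2 to compound 3 (3.50 log units; beyond the scatter), both large. The step of an at least 4.1-fold higher number from compound 1 to compound 2 (0.61 log units; beyond the scatter) only moves between pyridin-4-yl and pyridin-3-yl and bears little on this question. Compound 3 alone carries hydroxy and alone carries a ring of carbon only, while compound 4 keeps that ring and loses the hydroxy. In this assay a clear move to a higher number is therefore expected for compound 4, beyond the scatter yet short of a 770-fold lower number from compound 1 to compound 3 (2.89 log units; beyond the scatter). The expected change is a 13-fold higher number from compound 3 to compound 4 (1.11 log units; beyond the scatter). Compound 4 is estimated at 4000 nM, with an expected range from 400 nM to 60000 nM.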

Compound 4, half-maximal inhibitory concentration: 396000 nM
Beside the measured number, compound 4's estimate is 99-fold (2.00 log units) below it; the whole stated range lies below it.
By their numbers in this assay, from the lowest: compound 3; then compounds 1 and 4 (each within the scatter of the next). At a limit, above all of these: compound 2.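

In this assay, chloro in place of hydroxy on an aromatic carbon, para to a large group, gives a 1300-fold higher number from compound 3 to compound 4 (3.11 log units; beyond the scatter), the first exchange in the series made at this position alone, and it shows that the ring of carbon only does not by itself carry the low number of compound 3; among the compounds shown, that number goes with the 4-hydroxyphenyl group. The 4-chlorophenyl group also brings no separation from pyridin-4-yl, with a 1.7-fold higher number from compound 1 to compound 4 (0.22 log units; within the scatter), so these two groups cannot be ordered in this assay. The remaining step, an at least 2.5-fold lower number from compound 2 to compound 4 (0.40 log units; beyond the scatter), starts from a limit and not from a number: the limit of > 1000000 nM in this assay, at which 1 of the 4 values shown sits.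

The compounds shown leave open whether another group at this position, such as methoxy, an amine or a carboxylic acid, would keep a number close to that of compound 3, at 310 nM. They also do not tell what in the exchange of hydroxy for chloro produces the large step, since a single pair gives no basis for separating one explanation from another.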